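The compounds below may be only part of what the source reports. "The series", "measured", "known", "first", "only" and "open" are said of these compounds alone.

Measured so far:
- compound 1 `O=C(/C=C/C=C/c1ccc(F)cc1)N1CCCCC1`, an assay for inhibition of Polyunsaturated fatty acid 5-lipoxygenase (Homo sapiens), read by spectrophotometry, tested at 20 uM; on this read-out higher numbers stand for more inhibition at the one concentration tested (going by the name of the read-out) and lower numbers for less inhibition: 48.7%
- compound 2 `COc1cc(/C=C/C=C/C(=O)N2CCCCC2)cc(OC)c1OC`, this assay: 66.7%
- compound 3 `COc1cc(/C=C/C=C/C(=O)N2CCCCC2)cc(OC)c1O`, this assay: 32.7%

Compound 1 stands second highest of the three numbers in this assay: compound 3 is nearest to it, and compound 2 is furthest, with a higher number. Among the compounds with values here, the one step measured within the set, a number 34 percentage points lower from compound 2 to compound 3 (beyond the scatter), concerns a change on an oxygen and says nothing direct about the change now in view.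

Compound 4 `COc1ccc(/C=C/C=C/C(=O)N2CCCCC2)cc1` differs from compound 1 by methoxy in place of fluoro on an aromatic carbon. Within the data shown here, no measured pair bears on this exchange, so the expectation rests only on the spread of the three numbers: compound 2, carrying several methoxy groups, gives the highest value in this assay, while compound 1 with fluoro sits lower. The expected step of a number 3.3 percentage points higher from compound 1 to compound 4 (within the scatter) is therefore a small rise, not clearly beyond the scatter. For compound 4 in this assay the estimate is 52%, within a range of 35% to 70%.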

Compound 4, a percentage reported as inhibition, at one concentration (the size of the read-out at that concentration, not a potency): 42.6%
For compound 4 the middle estimate is 9.4 percentage points above the measured one; the measured number falls inside the stated range.
By their numbers in this assay, from the lowest: compounds 3, 4 and 1 (each within the scatter of the next, the first and the last beyond it); then compound 2.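

Placing methoxy instead of fluoro on this aromatic carbon, para to a large group, gives in this assay a number 6.1 percentage points lower from compound 1 to compound 4 (within the scatter). Within the data shown here, this is the first direct test of this position, and the two groups cannot be told apart on this read-out, even though methoxy brings one more heavy atom and one hydrogen-bond acceptor. No measurement here offers an explanation for this outcome.

As far as these compounds go, it remains open whether an amine, a carboxylic acid or a chlorine atom on the same aromatic carbon would give a number clearly different from those of fluoro and methoxy. It is also unclear whether this position matters more than other parts of the shared core, where a longer chain, for example, could be tested against compound 1.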